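Cytotoxicity notes on compounds 1 to 3

This account rests on a few compounds, and the source may have more. Where it says the series, first, only, none or still open, it means among the compounds named here.

Measured so far:
- Compound 1, `OB1OCc2ccc(-n3cc(Sc4ccc(F)cc4)c4ccccc43)cc21`: in an ADME assay on L929 cells (Mus musculus) for cytotoxicity, read by resazurin assay, with a stated time of 72 h (on this read-out higher numbers stand for weaker inhibition and lower numbers for stronger inhibition), compound 1 reaches only the assay limit, > 10 ug/mL.
- Compound 2, `O=C(c1ccn(-c2ccc3c(c2)B(O)OC3)c1)c1ccccc1Cl`: in this assay compound 2 likewise reaches only the assay limit, > 10 ug/mL.

Compound 2 therefore stands at the upper edge of what this read-out reports, and no number separates it from compound 1: both sit at the limit of > 10 ug/mL in this assay, at which 2 of the 2 values shown sit. Nothing here ranks the two against each other.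

Compound 3, `Cc1ccc(C(=O)c2ccn(-c3ccc4c(c3)B(O)OC4)c2)cc1`, is not yet measured. It differs from compound 2 in one place, (4-methylphenyl in place of 2-chlorophenyl on a carbonyl carbon), that is, 4-methylphenyl in place of 2-chlorophenyl on a carbonyl carbon. Among the measured compounds shown here, no pair of measured compounds shows a comparable change, so the size of this step cannot be read from the series; with both known values resting at the limit, no movement beyond the scatter is expected in this assay, and the most likely outcome is that compound 3 again reports only the limit. The step from compound 2 to compound 3 is estimated as a step that the limit leaves unreadable from compound 2 to compound 3. For compound 3 the expected value is 20 ug/mL, with a range from 8 ug/mL to 60 ug/mL.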

Compound 3, half-maximal inhibitory concentration: > 10 ug/mL
Compound 3 gave a limit, no number; the forecaster's own chance of this, stated with the estimate: 85%; the middle value lies beyond the limit too.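

No step can be read between compound 2 and compound 3, since both report only a limit: (the limit of > 10 ug/mL in this assay, at which 3 of the 3 values shown sit). The compounds shown leave open where any of the three would reach its half-maximal inhibitory concentration in this assay and whether 4-methylphenyl in place of 2-chlorophenyl on a carbonyl carbon changes cytotoxicity at all.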